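Replacing 4-chlorophenyl with naphthalen-2-yl

The compounds below may be only part of what the source reports. "The series", "measured", "known", "first", "only" and "open" are said of these compounds alone.

In a functional assay on BGC-823 cells (Homo sapiens) for inhibition, read by MTT assay, with a stated time of 72 h (a higher number here means a weaker inhibitor, a lower number a stronger inhibitor), compound 1 `O=C1/C(=C\c2ccccc2)c2c(ncn2COCc2ccccc2)CCN1Cc1ccccc1` gives 20400 nM while compound 2 `Cc1cc(C)cc(CN2CCc3ncn(COCc4ccccc4)c3/C(=C/c3ccccc3)C2=O)c1` gives 52600 nM and compound 3 `O=C1/C(=C\c2ccccc2)c2c(ncn2COCc2ccccc2)CCN1Cc1ccc(Cl)cc1` gives 75700 nM as its value. Compound 3 sits at the weak end of this small set, yet a 1.4-fold higher number from compound 2 to compound 3 (0.16 log units; within the scatter) stays within the usual scatter. The change to compound 4 `O=C1/C(=C\c2ccccc2)c2c(ncn2COCc2ccccc2)CCN1Cc1ccc2ccccc2c1` is naphthalen-2-yl in place of 4-chlorophenyl on a saturated chain carbon bound to an amide-type nitrogen in a ring. Among the compounds with values here, no measured compound carries naphthalen-2-yl. Changes to this group have so far given a 2.6-fold higher number from compound 1 to compound 2 (0.41 log units; beyond the scatter) and a 3.7-fold higher number from compound 1 to compound 3 (0.57 log units; beyond the scatter) as modest steps, so a modest drop or nothing beyond the scatter is expected. In this assay the estimated result is a 1.7-fold lower number from compound 3 to compound 4 (0.23 log units; within the scatter) as the expected step. Compound 4 is estimated at 45000 nM (expected range 15000 nM to 120000 nM).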

Compound 4, half-maximal inhibitory concentration: 93300 nM
For compound 4 the middle estimate is 2.1-fold (0.32 log units) below the measured one; measured number inside the range.
By their numbers in this assay, from the lowest: compound 1; then compounds 2, 3 and 4 (each within the scatter of the next).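

In this assay, naphthalen-2-yl, with its two six-membered aromatic rings, cannot be told apart from either substituted phenyl group, with a 1.2-fold higher number from compound 3 to compound 4 (0.09 log units; within the scatter) and a 1.8-fold higher number from compound 2 to compound 4 (0.25 log units; within the scatter). Only the plain phenyl group stands apart, with a 4.6-fold higher number from compound 1 to compound 4 (0.66 log units; beyond the scatter), so all three replacements of phenyl shown here give higher numbers, whether they add chloro, two methyl groups or a second aromatic ring. No measurement available here accounts for this result. As far as these compounds go, it remains open whether a pyridine ring, or a phenyl ring carrying an amine or a carboxylic acid, would give a lower number than plain phenyl at this position.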